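An aryl swap carried from an ester to an amide

A few compounds are considered here, and "the series" means these few. Any claim that something is new, unique, unknown or untested is made for them only; others in the source may bear on it.

Compound 1 `Cc1c(Cl)cccc1C(=O)OC(CCN(C)C)c1ccc(Cl)cc1`: 118%
Compound 2 `Cc1ccc(C)c(C(=O)OC(CCN(C)C)c2ccc(Cl)cc2)c1`: 86%
Compound 3 `Cc1c(Cl)cccc1C(=O)NC(CCN(C)C)c1ccc(Cl)cc1`: 142%

In an assay on NIH3T3 cells with Urotensin-2 receptor (Homo sapiens) as the target (a higher number here means a larger maximal response, a lower number a smaller maximal response), compound 3 gives 142%, the highest of the three; compound 1 gives 118% and compound 2 gives 86%. The difference between the cores of compound 1 and compound 3 is not broken down here. On the core of compound 1, the change 2,5-dimethylphenyl in place of 3-chloro-2-methylphenyl on a carbonyl carbon gave a number 32 percentage points lower from compound 1 to compound 2 (beyond the scatter). Compound 4 `Cc1ccc(C)c(C(=O)NC(CCN(C)C)c2ccc(Cl)cc2)c1` carries the same kind of change on the core of compound 3, (2,5-dimethylphenyl in place of 3-chloro-2-methylphenyl on a carbonyl carbon); around the place, the carbonyl carbon here has an amide-type nitrogen as its other neighbour, whereas in compound 1 it has an oxygen next to a carbonyl group. Because the earlier step was a number 32 percentage points lower from compound 1 to compound 2 (beyond the scatter), a step of similar size is expected here, and the expected change is a number 32 percentage points lower from compound 3 to compound 4 (beyond the scatter). Compound 4 is therefore estimated at 110%, between 85% and 135% in this assay.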

Compound 4, largest response reached (reported as efficacy), in percent of the reference or control that the assay uses: 164%
Beside the measured number, compound 4's estimate is 54 percentage points below it, outside the stated range (above it).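

In this assay, the change to 2,5-dimethylphenyl on the core of compound 3 gave a number 22 percentage points higher from compound 3 to compound 4 (beyond the scatter), so the earlier step did not carry over. The same change went in opposite directions on the two cores: the same change on two cores in this assay, a number 32 percentage points lower (beyond the scatter) from compound 1 to compound 2 and a number 22 percentage points higher (beyond the scatter) from compound 3 to compound 4, 54 percentage points apart, beyond the scatter of two such steps. Among the compounds shown here, this shows that, for these compounds, the step on one core does not predict the step on the other, but with only one pair on each core it does not show why the two differ or whether the reversal extends to other aryl groups.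

The compounds shown leave open whether an unsubstituted phenyl or a 4-methoxyphenyl on the carbonyl carbon would also behave differently on the two cores. They also leave open whether a pyrrolidine in place of the dimethylamine would alter the pattern.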